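A few compounds are considered here, and "the series" means these few. Any claim that something is new, unique, unknown or untested is made for them only; others in the source may bear on it.

Measured so far:
- compound 1, `O=C(CCCCC[C@H](NC(=O)OCc1ccccc1)C(=O)NCc1ccccc1)NO`: 1520 nM
- compound 2, `O=C(CCCCC[C@H](NC(=O)c1ccc(Br)cc1)C(=O)NCc1ccncc1)NO`: 5240 nM
- compound 3, `O=C(CCCCC[C@H](NC(=O)OCc1ccccc1)C(=O)NC1CCCc2ccccc21)NO`: 1700 nM

In a functional assay on NFF cells (Homo sapiens) for antiproliferative activity (on this read-out higher numbers stand for weaker inhibition and lower numbers for stronger inhibition), compound 3 gives 1700 nM, the second highest of the three numbers. Compound 1 lies within the scatter of it, at 1520 nM. Compound 2 sits furthest away, with 5240 nM, a gap beyond the scatter; compound 2 differs from compound 3 in more than one place, so only its value itself is informative here.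

The next compound is compound 4, `O=C(CCCCC[C@H](NC(=O)OCc1ccccc1)C(=O)Nc1cccc2cccnc12)NO`, not yet measured. The change from compound 3 is quinolin-8-yl in place of 1,2,3,4-tetrahydronaphthalen-1-yl on an amide-type nitrogen. For the measured compounds named here, one measured step bears on it: a 1.1-fold higher number from compound 1 to compound 3 (0.05 log units; within the scatter), showing that exchanging the group on this amide-type nitrogen left this assay essentially unchanged. Going by the values given here, no measured pair shows an aromatic group with a hydrogen-bond acceptor placed directly on this nitrogen, so the uncertainty is wider than that single step suggests.

Compound 4 is therefore expected near 2000 nM, with a range of 700 nM to 6000 nM. This estimate means a 1.2-fold higher number from compound 3 to compound 4 (0.07 log units; within the scatter), expected to remain within the scatter.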

Compound 4, half-maximal inhibitory concentration: 452 nM
Estimate against measurement, compound 4: 4.4-fold (0.65 log units) above; measured number below the stated range.
By their numbers in this assay, from the lowest: compound 4; then compounds 1 and 3 (each within the scatter of the next); then compound 2.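

In this assay the group on this amide-type nitrogen does move the number: a 3.8-fold lower number from compound 3 to compound 4 (0.58 log units; beyond the scatter) with quinolin-8-yl in place of 1,2,3,4-tetrahydronaphthalen-1-yl, and a 3.4-fold lower number from compound 1 to compound 4 (0.53 log units; beyond the scatter) with quinolin-8-yl in place of benzyl. The earlier exchange gave only a 1.1-fold higher number from compound 1 to compound 3 (0.05 log units; within the scatter) and stayed within the scatter, so that step does not hold for every group at this position. No measurement on hand accounts for the lower number of compound 4.

Quinolin-8-yl differs from 1,2,3,4-tetrahydronaphthalen-1-yl in both its second aromatic ring and its ring nitrogen, and the compounds shown do not separate the two. A naphthalen-1-yl group on the same nitrogen would test the ring nitrogen alone, while a quinolin-5-yl group would test where that nitrogen sits.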